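Removing the 4-fluorobenzyl Group: What to Expect

The source may report more compounds than this note shows. Statements on the series, on what has been measured and on what is new or still open speak of the compounds shown alone.

Of the compounds shown here, two have so far been tested in an ADME assay on CHO cells (Cricetulus griseus) for inhibition, read by MTT assay; on this read-out lower numbers stand for stronger inhibition and higher numbers for weaker inhibition. Compound 1 `CC(C)(C)NCc1cc(Cl)cc(Nc2nc3ccccc3[nH]2)c1O` gives only a limit in this assay, > 50000 nM. That value sits at the limit of > 50000 nM in this assay, at which 1 of the 2 values shown sits. For the measured compounds named here, compound 2 `CCN(CC)Cc1cc(C)cc(Nc2nc3ccccc3n2Cc2ccc(F)cc2)c1O` gives the one actual number in this assay, 18700 nM. Compound 3 `CCN(CC)Cc1cc(C)cc(Nc2nc3ccccc3[nH]2)c1O` differs from compound 2 by hydrogen in place of 4-fluorobenzyl on an aromatic nitrogen. Going by the values given here, no measured pair isolates this change, so the expectation rests on those two values alone. A weakening beyond the scatter is expected, a 2.1-fold higher number from compound 2 to compound 3 (0.33 log units; beyond the scatter), with a real chance that only a limit is reported. Compound 3 is estimated at 40000 nM, expected to fall between 12000 nM and 100000 nM.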

Compound 3, half-maximal inhibitory concentration: > 50000 nM
Compound 3: a limit, no number; the forecaster's own chance of this, stated with the estimate: 40%; middle value at least 1.2-fold (0.09 log units) from the limit.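

Replacing the 4-fluorobenzyl group on the aromatic nitrogen with hydrogen gives an at least 2.6-fold higher number from compound 2 to compound 3 (0.42 log units; beyond the scatter) in this assay, so this position matters, and having the group there goes with stronger inhibition. Compound 3 gives only a limit, not a number, so the full size of this step cannot be told: the limit of > 50000 nM in this assay, at which 2 of the 3 values shown sit.

From the compounds shown here alone, it remains open whether the whole 4-fluorobenzyl group is needed here. A plain benzyl group would test the fluorine, while a methyl group or a longer chain such as phenethyl would test the size and reach of the group.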